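Chloro on the pendant phenyl of the acetylated sulfonamide

A few compounds are considered here, and "the series" means these few. Any claim that something is new, unique, unknown or untested is made for them only; others in the source may bear on it.

Two members of the series have been measured in a functional assay on cells (Cancer cell lines, Homo sapiens) for cytotoxicity, read by sulforhodamine B assay, with a stated time of 48 h; on this read-out lower numbers stand for stronger inhibition of growth and higher numbers for weaker inhibition of growth. Compound 1 `NS(=O)(=O)c1ccc(-n2nc(-c3ccc(Cl)cc3)cc2-c2cc(O)ccc2O)cc1` carries a free sulfonamide and a 4-chlorophenyl group and gives 43100 nM. Compound 2 `CC(=O)NS(=O)(=O)c1ccc(-n2nc(-c3ccccc3)cc2-c2cc(O)ccc2O)cc1` carries an acetylated sulfonamide and an unsubstituted phenyl group and gives 100000 nM. Compound 2 stands at the highest of the two numbers; compound 1 sits at a lower value, and the gap between them lies beyond the usual scatter. The two measured compounds differ in two places at once. Within the data shown here, no single-change step is available between them.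

Compound 3 `CC(=O)NS(=O)(=O)c1ccc(-n2nc(-c3ccc(Cl)cc3)cc2-c2cc(O)ccc2O)cc1` is the next member to be measured. Relative to compound 2 the change is chloro in place of hydrogen on an aromatic carbon, so compound 3 pairs the acetylated sulfonamide of compound 2 with the 4-chlorophenyl group of compound 1. In this assay, among the measured compounds shown here, a modest move toward a lower number is expected, since compound 1, the only chloro-bearing member, gives 43100 nM; the expected step of a 1.7-fold lower number from compound 2 to compound 3 (0.22 log units; within the scatter) remains small against the scatter. Compound 3 is expected to give 60000 nM, in a range from 25000 nM to 100000 nM.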

Compound 3, concentration for total growth inhibition: 66600 nM
Compound 3: the middle estimate sits 1.1-fold (0.05 log units) below what was measured; the measured number falls inside the stated range.
By their numbers in this assay, from the lowest: compounds 1, 3 and 2 (each within the scatter of the next, the first and the last beyond it).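

Chloro in place of hydrogen on the pendant ring, para to a large group, can now be read alone on the acetylated sulfonamide: in this assay it gives a 1.5-fold lower number from compound 2 to compound 3 (0.18 log units; within the scatter), so this single change does not separate from the scatter. Acetyl in place of hydrogen on the sulfonamide nitrogen can also be read alone for the first time, with the 4-chlorophenyl group held constant, and it gives a 1.5-fold higher number from compound 1 to compound 3 (0.19 log units; within the scatter), again without leaving the scatter. Neither step can therefore be given a direction on these numbers, and nothing at hand bears on the reasons for their size.

On these data alone, whether a different group at this place on the ring, such as methoxy, an amine or a carboxylic acid, would give a step beyond the scatter remains open, as does the outcome of a longer acyl chain, such as propionyl, on the sulfonamide nitrogen. Also open, as far as these compounds go, is how the phenyl to 4-chlorophenyl change reads on the free sulfonamide, and whether the two single changes act independently of each other on the shared core.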